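Fluoro for methyl on the outer phenyl ring

The compounds below may be only part of what the source reports. "The series", "measured", "known", "first", "only" and "open" are said of these compounds alone.

Two compounds of this series carry a measurement. Compound 1 `Cc1ccc(-c2ccc(F)cc2)n1-c1ccc(-c2nc3ccc(F)cc3s2)cc1` gives 2800 nM in a functional assay on MCF7 cells (Homo sapiens) for cytotoxicity, read by MTT assay, with a stated time of 72 h; on this read-out lower numbers stand for stronger inhibition and higher numbers for weaker inhibition. Compound 2 `COc1ccc2nc(-c3ccc(-n4c(C)ccc4-c4ccc(C)cc4)cc3)sc2c1` gives 2850 nM in this assay. On the numbers shown compound 2 stands alongside compound 1: the two values fall within the scatter of one another, and the read-out does not separate them.

Compound 3 `COc1ccc2nc(-c3ccc(-n4c(C)ccc4-c4ccc(F)cc4)cc3)sc2c1` has not been measured. It differs from compound 2 in a single place: fluoro in place of methyl on an aromatic carbon. Within the data shown here, no measured pair shows this same exchange, so its effect cannot be read from the data. Among the measured compounds shown here, the only comparison available, compound 1 against compound 2, differs at more than one place and cannot be taken apart into single contributions. The expected step from compound 2 to compound 3, a 1.1-fold lower number from compound 2 to compound 3 (0.02 log units; within the scatter), is therefore taken as no larger than the scatter, with no preferred direction. Compound 3 is estimated at 2700 nM, with a range from 1300 nM to 5600 nM.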

Compound 3, half-maximal inhibitory concentration: 2800 nM
Compound 3: middle estimate off by 1.0-fold (0.02 log units), on the low side; measured number inside the range.
By their numbers in this assay, from the lowest: compounds 1, 3 and 2 (each within the scatter of the next).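

In this assay, among these compounds, the exchange of 4-methylphenyl for 4-fluorophenyl gives a 1.0-fold lower number from compound 2 to compound 3 (0.01 log units; within the scatter) and so provides the first single-place reading at this position, where the read-out does not separate fluoro from methyl. Compound 3 also links compound 1 and compound 2 through one-place comparisons, which their direct comparison could not offer: methoxy in place of fluoro on an aromatic carbon of the shared core gives no change at the digits printed from compound 1 to compound 3 (within the scatter) and is likewise not separated by the read-out. No measurement at hand bears on the reason for either result.

The compounds shown cover only methyl and fluoro on the outer phenyl ring and only fluoro and methoxy on the shared core, so neither position has yet been read with a group of a different kind. Going by these compounds, whether an amine or a carboxylic acid on the outer phenyl ring, or a longer alkoxy chain in place of methoxy on the core, would give a number beyond the scatter in this assay remains open.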